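Swapping Phenyl for Pyridin-3-yl on Compound 1

The source may hold more compounds than are shown below. What is called first, only, known or untested is meant among the compounds shown, and "the series" means these compounds.

In a functional assay on MCF7 cells (Homo sapiens) for cytotoxicity, read by WST assay, with a stated time of 72 h (a lower number here means a stronger inhibitor, a higher number a weaker inhibitor), compound 1 `O=C1Nc2c(ccc(F)c2F)C1(c1ccccc1)c1ccc(O)cc1` gives 7.1 nM, the lowest of the two single numbers available. The other single number belongs to compound 3 `O=C1Nc2c(ccc(F)c2F)C1(c1ccncc1)c1ccc(O)cc1`, which gives 37 nM. Compound 2 `COc1ccc(C2(c3ccc(O)cc3)C(=O)Nc3c2ccc(F)c3F)cc1` has several entries, 2.1 nM; 6.3 nM; > 1000 nM (3 entries). The last of these entries for compound 2 is a limit and not a number, so compound 2 has no single value to rank.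

The next compound is compound 4 `O=C1Nc2c(ccc(F)c2F)C1(c1ccc(O)cc1)c1cccnc1`, where the change is pyridin-3-yl in place of phenyl on a saturated ring carbon. Within the data shown here, one measured step bears on it: a 5.2-fold higher number from compound 1 to compound 3 (0.72 log units; beyond the scatter), with pyridin-4-yl in place of phenyl at the same place. That step is modest but beyond the scatter. A step of similar size towards a higher number in this assay is therefore expected, though this rests on a single comparison. The expected change is a 3.5-fold higher number from compound 1 to compound 4 (0.55 log units; beyond the scatter). For compound 4, the estimated value is 25 nM, with an expected range from 7 nM to 90 nM.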

Compound 4, half-maximal inhibitory concentration: 63 nM
Compound 4: middle estimate off by 2.5-fold (0.40 log units), on the low side, within the range that was stated.
By their numbers in this assay, from the lowest: compound 1; then compounds 3 and 4 (each within the scatter of the next).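

Both pyridine rings now give a higher number than phenyl on this saturated ring carbon in this assay, so the earlier step to pyridin-4-yl is no longer a lone case: the new step is beyond the scatter (an 8.9-fold higher number from compound 1 to compound 4 (0.95 log units; beyond the scatter)). Where the ring nitrogen sits in the pyridine makes no readable difference here, since pyridin-3-yl and pyridin-4-yl lie within the scatter of each other (a 1.7-fold higher number from compound 3 to compound 4 (0.23 log units; within the scatter)). Nothing shown here explains why either pyridine differs from phenyl.

The compounds shown leave open how pyridin-2-yl would read on this carbon, which would complete the set of pyridine isomers. They also leave open whether a phenyl ring carrying an amine or a carboxylic acid would stay as low as the unsubstituted phenyl of compound 1.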